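The compounds below may be only part of what the source reports. "The series", "measured", "known", "first", "only" and "open" are said of these compounds alone.

Measured compounds:
- compound 1 `O=C(O)CCc1ccc(NCc2cccc(-c3ccccc3)c2)cc1`: 101%
- compound 2 `Cc1ccc(-c2cccc(CNc3ccc(CCC(=O)O)cc3)c2)cc1`: 92%

In a functional assay on 1321-N1 cells for agonist activity at Free fatty acid receptor 1 (Homo sapiens), read by calcium flux (a higher number here means a larger maximal response, a lower number a smaller maximal response), compound 1 gives 101%, and compound 2 gives 92%. Among the compounds with values here, the one comparison available is a number 9 percentage points lower from compound 1 to compound 2 (within the scatter), so the two measured compounds cannot be told apart; compound 2 simply carries the lower of the two numbers, with the gap to compound 1 inside the scatter.

Compound 3 `COc1ccccc1-c1cccc(CNc2ccc(CCC(=O)O)cc2)c1` is the next compound, differing from compound 2 by 2-methoxyphenyl in place of 4-methylphenyl on an aromatic carbon. Within the data shown here, the only measured step that bears on this is a number 9 percentage points lower from compound 1 to compound 2 (within the scatter), which also altered the same outer ring and produced no change beyond the scatter. On that basis the expected step is a number 3 percentage points higher from compound 2 to compound 3 (within the scatter), meaning no movement beyond the scatter is expected. Compound 3 is therefore estimated at 95%, with a range from 78% to 112%.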

Compound 3, largest response reached (reported as efficacy), in percent of the reference or control that the assay uses: 109%
The estimate for compound 3 lay 14 percentage points below the measured number; the range from low to high includes it.
By their numbers in this assay, from the lowest: compounds 2, 1 and 3 (each within the scatter of the next, the first and the last beyond it).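

In this assay, within the data shown here, 2-methoxyphenyl in place of 4-methylphenyl on this aromatic carbon gives the first step beyond the scatter (a number 17 percentage points higher from compound 2 to compound 3 (beyond the scatter)), so a change to this outer ring can move the maximal response. The step is modest, and methoxy in place of hydrogen stays within the scatter (a number 8 percentage points higher from compound 1 to compound 3 (within the scatter)), so only compound 2 and compound 3 can be told apart, while neither can be told apart from compound 1. No measurement available here accounts for the step.

Compound 2 and compound 3 differ in both the group and where it sits on the outer ring, so the contribution of each remains unresolved. From the compounds shown here alone, whether a fluorine or an amine at either place would give a similar response also remains open.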